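This account rests on a few compounds, and the source may have more. Where it says the series, first, only, none or still open, it means among the compounds named here.

Measured compounds in an ADME assay on the whole organism with Oryza sativa as the target, tested at 10 uM; a lower number here means a stronger effect, a higher number a weaker effect of the compound at the concentration tested:

compound 1, `Cc1cccc(NC(=O)N[C@@H](C)c2ccccc2)c1`, gives 100%
compound 2, `Cc1ccc(NC(=O)N[C@H](C)c2ccccc2)cc1`, gives 64%
compound 3, `CCc1cccc(NC(=O)N[C@@H](C)c2ccccc2)c1`, gives 86%

Compounds 1 and 3 share a core and differ in one place: methyl in place of hydrogen on a saturated chain carbon bound to an aromatic carbon. In this assay this change made a step of a number 14 percentage points lower from compound 1 to compound 3 (beyond the scatter). Compound 2 is built from the same atoms as compound 1, joined differently; the difference between the two cores is not broken down here. Compound 2 stands lowest of the three measured numbers, with compound 3 above it and compound 1 furthest above it.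

Compound 4, `CCc1ccc(NC(=O)N[C@H](C)c2ccccc2)cc1`, has not yet been measured. It stands to compound 2 as compound 3 stands to compound 1: methyl in place of hydrogen on a saturated chain carbon bound to an aromatic carbon. The place of the change is the same in both pairs.

For the measured compounds named here, with only one measured instance of this change, the expectation for compound 4 rests on compound 2 with its value of 64% and on the single step seen from compound 1 to compound 3 in this assay. The step from compound 2 to compound 4 is therefore expected to be about a number 14 percentage points lower from compound 2 to compound 4 (beyond the scatter) in this assay, of similar size to the earlier one, though a different core may not carry the change the same way. Compound 4 is estimated at 50% in this assay. The range expected for compound 4 runs from 34% to 68%.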

Compound 4, a percentage reported as activity, at one concentration (the size of the read-out at that concentration, not a potency): 44%
Compound 4: the middle estimate sits 6 percentage points above what was measured; low and high end bracket the measured number.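

On the core of compound 2 in this assay, methyl in place of hydrogen on a saturated chain carbon bound to an aromatic carbon, which turns the methyl group into an ethyl group, gave a number 20 percentage points lower from compound 2 to compound 4 (beyond the scatter) and so moved the number in the same direction as it had on the core of compound 1. Set side by side, the two steps cannot be told apart in size: the same change on two cores in this assay, a number 14 percentage points lower (beyond the scatter) from compound 1 to compound 3 and a number 20 percentage points lower (beyond the scatter) from compound 2 to compound 4, 6 percentage points apart, within the scatter of two such steps. For the compounds shown here, this shows that, within this series, the step seen on one core was a usable guide to the step on the other, but it rests on only two pairs of compounds and does not show that the change would carry over in the same way to any further core, nor does it give any reason why the number drops on either core.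

The compounds shown leave open whether a longer chain such as propyl, or an amine or a carboxylic acid at the same place, would continue this drop, level it off or reverse it. They also leave open whether a hydroxyl group there would behave like the methyl group on both cores alike.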